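Pyridin-3-yl to pyrimidin-5-yl on the amide nitrogen

The source may report more compounds than this note shows. Statements on the series, on what has been measured and on what is new or still open speak of the compounds shown alone.

Compound 1: `CCc1cccc(NC(=O)CN2CCN(c3ccccn3)CC2)c1`, 133 nM
Compound 2: `O=C(CN1CCN(c2ccccn2)CC1)Nc1cccnc1`, 2660 nM
Compound 3: `O=C(CN1CCN(c2ccc(Cl)cn2)CC1)Nc1cccnc1`, "not active" (no number reported)

The series shares a piperazine-acetamide core. In an assay on cells for agonist activity at D(4) dopamine receptor (Homo sapiens), read by luminescence and beta-arrestin recruitment, with a stated time of 90 min (a higher number here means that more compound is needed for the effect, a lower number that less compound is needed), compound 1 gives 133 nM. In this assay, among the compounds with values here, compound 2 gives 2660 nM, the highest of the two numbers reported; the only step recorded at this position, a 20-fold higher number from compound 1 to compound 2 (1.30 log units; beyond the scatter), separates it from compound 1. Compound 3, which differs from compound 2 in its pyridine on the piperazine rather than at the amide nitrogen, was reported as not active with no number, so it tells nothing about the amide-side change.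

Compound 4, `O=C(CN1CCN(c2ccccn2)CC1)Nc1cncnc1`, is not yet measured. Its change from compound 2 is pyrimidin-5-yl in place of pyridin-3-yl on an amide-type nitrogen. Within the data shown here, the one step that bears on this position, a 20-fold higher number from compound 1 to compound 2 (1.30 log units; beyond the scatter), was large and went toward a higher number when a ring carbon was exchanged for a ring nitrogen; the present change repeats that kind of exchange. Compound 4 is therefore expected to give a higher number than compound 2, with a step of about a 3.0-fold higher number from compound 2 to compound 4 (0.48 log units; beyond the scatter). Compound 4 is estimated at 8000 nM, within a range of 2500 nM to 30000 nM.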

Compound 4, half-maximal effective concentration: "not active" (no number reported)
No number was reported for compound 4; the estimate stays without a comparison.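

Compound 4, like compound 3, was reported as not active in this assay with no number, so no step can be read from compound 2 to compound 4. No measurement shown here bears on this result. From the compounds shown here alone, the size of any change on replacing pyridin-3-yl with pyrimidin-5-yl on the amide-type nitrogen remains open.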